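Working notes: cytotoxicity of compounds 1, 2 and 3

The source may hold more compounds than are shown below. What is called first, only, known or untested is meant among the compounds shown, and "the series" means these compounds.

Measured so far, read in an ADME assay on HEK293 cells (Homo sapiens) for cytotoxicity, read by ATP content, with a stated time of 6 h; on this read-out higher numbers stand for lower toxicity in this test and lower numbers for higher toxicity in this test:
compound 1 `CCCCNc1nc(N)nc2ccn(Cc3ccc4ccccc4n3)c12` gives > 24000 nM, a limit of the assay.
compound 2 `COCCNc1nc(N)nc2ccn(Cc3ccccn3)c12` gives > 24000 nM, a limit of the assay.

Compound 2 stands where every number shown stands, at the limit of > 24000 nM in this assay, at which 2 of the 2 values shown sit. Going by the values given here, neither value shown is a number, so no step between compound 1 and compound 2 can be measured in this assay, and no order between them is known. Compound 3 `Nc1nc(NCc2ccon2)c2c(ccn2Cc2ccccn2)n1` differs from compound 2 in one place: 1,2-oxazol-3-yl in place of methoxymethyl on a saturated chain carbon bound to a nitrogen on an aromatic ring. Among the compounds with values here, no step between measured compounds is available to size what this change does in this assay, and the two values shown only say that neither compound 1 nor compound 2 reaches a measurable toxicity within the tested range. The step expected from compound 2 to compound 3 in this assay is a step that the limit leaves unreadable from compound 2 to compound 3, that is, none beyond the scatter, since both values shown sit at the limit of > 24000 nM in this assay, at which 2 of the 2 values shown sit. For compound 3 the estimate in this assay is 30000 nM, with a range from 12000 nM to 80000 nM, and most likely the assay will again report only a limit.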

Compound 3, half-maximal cytotoxic concentration: > 24000 nM
Compound 3: only a limit was reported; the forecaster's own chance of this, stated with the estimate: 80%; the middle value is on the limit's open side.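

In this assay compound 3 gives > 24000 nM, a limit of the assay. No step from compound 2 to compound 3 can be read, as both values are limits: the limit of > 24000 nM in this assay, at which 3 of the 3 values shown sit.

The compounds shown leave open what 1,2-oxazol-3-yl in place of methoxymethyl does in this assay, since none of compound 1, compound 2 or compound 3 gives a number there.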